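Methyl in place of methoxy on compound 2

The source may report more compounds than this note shows. Statements on the series, on what has been measured and on what is new or still open speak of the compounds shown alone.

Compound 1 `Cc1ccc2c(S)nc(-c3ccccc3)cc2c1` gives 19100 nM; 41900 nM (2 entries)
Compound 2 `COc1ccc(-c2cc3cc(C)ccc3c(N3CCN(C)CC3)n2)cc1` gives 9330 nM

Both compounds were tested in a functional assay on HCT-15 cells (Homo sapiens) for cytotoxicity; a lower number here means a stronger inhibitor, a higher number a weaker inhibitor. For compound 2, 9330 nM is the only number shown, and a further entry gives no single number. Compound 3 `Cc1ccc(-c2cc3cc(C)ccc3c(N3CCN(C)CC3)n2)cc1` has methyl in place of methoxy on an aromatic carbon, para to a large group methyl in place of methoxy on an aromatic carbon and still awaits measurement. For the measured compounds named here, no measured pair shows this change, so compound 2 at 9330 nM serves as the anchor. The expectation in this assay is no shift beyond the scatter. The expected result is a 1.0-fold lower number from compound 2 to compound 3 (0.02 log units; within the scatter) as a step. Compound 3 is estimated at 9000 nM with an expected range from 3500 nM to 24000 nM around that figure.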

Compound 3, half-maximal inhibitory concentration: 8320 nM
The estimate for compound 3 lay 1.1-fold (0.03 log units) above the measured number, and the stated range covers the measured number.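

In this assay, for the compounds shown here, this swap can now be read directly for the first time, and it gives a 1.1-fold lower number from compound 2 to compound 3 (0.05 log units; within the scatter). Compounds with 4-methoxyphenyl and 4-methylphenyl therefore read alike, so the oxygen and its hydrogen-bond acceptor are not needed for this cell result. A gap this small is modest beside repeat readings of a single compound: the several entries of compound 1 in this assay, 19100 nM; 41900 nM (2 entries)

Only methoxy and methyl can be compared at this position. On these data alone, how an amine or a carboxylic acid there would read remains open.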